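This account rests on a few compounds, and the source may have more. Where it says the series, first, only, none or still open, it means among the compounds named here.

Two compounds have been measured so far:
compound 1 `O=c1ccoc2ccc(OCc3cccc(Br)c3)cc12`, 2 nM in an assay on microsomes for inhibition of Amine oxidase [flavin-containing] B (Homo sapiens), read by fluorescence and spectrophotometry, with a stated time of 20 min; a lower number here means a stronger inhibitor, a higher number a weaker inhibitor
compound 2 `O=c1ccoc2ccc(OCc3ccc(Br)cc3)cc12`, 3.3 nM in this assay

Compound 1 and compound 2 give numbers that lie within the usual scatter of each other, so neither stands apart in this assay. Compound 3 `N#Cc1cccc(COc2ccc3occc(=O)c3c2)c1` has not yet been measured. It differs from compound 1 in one place: cyano in place of bromo on an aromatic carbon. Among the measured compounds shown here, no step between measured compounds shows what such a change does, so the expectation rests on compound 1 alone. A modest move toward a weaker inhibitor is expected, a 2.5-fold higher number from compound 1 to compound 3 (0.40 log units; beyond the scatter). Compound 3 is estimated to give 5 nM, within 1.5 nM to 20 nM.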

Compound 3, half-maximal inhibitory concentration: 76 nM
Estimate against measurement, compound 3: 15-fold (1.18 log units) below, and the stated range ends below it.
By their numbers in this assay, from the lowest: compounds 1 and 2 (each within the scatter of the next); then compound 3.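

Replacing bromo with cyano on this aromatic carbon, meta to a large group, is far from a neutral exchange: in this assay it gives a 38-fold higher number from compound 1 to compound 3 (1.58 log units; beyond the scatter). Compound 1 and compound 2 both carry bromo, so only compound 3 shows how strongly the number depends on the group at this place. Nothing measured here explains why the number rises so much. From the compounds shown here alone, it remains open whether chloro, methyl or methoxy at this carbon would stay close to compound 1, and whether cyano in place of the bromo of compound 2 would bring a similar rise.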